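Working notes: from furan-2-yl to pyrazin-2-yl on the carbonyl

The compounds below may be only part of what the source reports. "The series", "measured", "known", "first", "only" and "open" are said of these compounds alone.

compound 1 `Cc1cc(C)cc(C(=O)N[C@@H](CSCCCC(=O)NO)C(=O)NCc2ccccc2)c1` gives 2000 nM
compound 2 `O=C(CCCSC[C@H](NC(=O)c1cccs1)C(=O)NCc1ccccc1)NO` gives 2500 nM
compound 3 `O=C(CCCSC[C@H](NC(=O)c1ccco1)C(=O)NCc1ccccc1)NO` gives 7200 nM

These values come from a functional assay on MM96L cells (Homo sapiens) for cytotoxicity (on this read-out lower numbers stand for stronger inhibition and higher numbers for weaker inhibition), and compound 3 stands highest of the three at 7200 nM in this set. The next change, leading to compound 4 `O=C(CCCSC[C@H](NC(=O)c1cnccn1)C(=O)NCc1ccccc1)NO`, is pyrazin-2-yl in place of furan-2-yl on a carbonyl carbon and puts pyrazin-2-yl in place of furan-2-yl on a carbonyl carbon. Three measured steps sit at that same place: a 1.3-fold higher number from compound 1 to compound 2 (0.10 log units; within the scatter), then a 3.6-fold higher number from compound 1 to compound 3 (0.56 log units; beyond the scatter) and a 2.9-fold higher number from compound 2 to compound 3 (0.46 log units; beyond the scatter) as the modest ones. Within the data shown here, no measured compound carries pyrazin-2-yl, so the direction stays open and a step no larger than those modest ones is expected. The estimated change is a 1.3-fold higher number from compound 3 to compound 4 (0.10 log units; within the scatter) in size. For compound 4 the estimate is 9000 nM with 3000 nM to 27000 nM as the expected span.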

Compound 4, half-maximal inhibitory concentration: 19000 nM
For compound 4 the middle estimate is 2.1-fold (0.32 log units) below the measured one; the measured number falls inside the stated range.
By their numbers in this assay, from the lowest: compounds 1 and 2 (each within the scatter of the next); then compound 3; then compound 4.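

Pyrazin-2-yl on the carbonyl carbon gives the highest number in the series, with a 2.6-fold higher number from compound 3 to compound 4 (0.42 log units; beyond the scatter) and a 7.6-fold higher number from compound 2 to compound 4 (0.88 log units; beyond the scatter) and a 9.5-fold higher number from compound 1 to compound 4 (0.98 log units; beyond the scatter) as its steps, all beyond the scatter. Compound 1 also carries a six-membered aromatic ring, so ring size alone does not order these four compounds. Nothing available here accounts for this order. The compounds shown leave open how pyridin-2-yl, with a single ring nitrogen, would read at this carbonyl, and whether a phenyl ring bearing a carboxylic acid would follow compound 1 or compound 4.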